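Two Ring Stereocentres Flipped in an Inactive Series

The compounds below may be only part of what the source reports. "The series", "measured", "known", "first", "only" and "open" are said of these compounds alone.

Compound 1, `CCOC(=O)[C@@H]1C[C@@]23CN(C)C[C@@H](CCC4=C2[C@H]1CC4=O)C31CC[C@](CC)(OC)OC1`, in a functional assay on HL-60 cells (Homo sapiens) for cytotoxicity, read by MTT assay, with a stated time of 48 h (on this read-out lower numbers stand for stronger inhibition and higher numbers for weaker inhibition), gives > 40000 nM, which is a limit of the assay and not a number. Compound 2, `CC[C@]1(OC)CCC2(CO1)[C@@H]1CCC3=C4[C@H](CC3=O)[C@H](C(=O)OC)C[C@@]42CN(C)C1`, gives > 40000 nM in this assay, again a limit. Compound 3, `CC[C@@]1(OC)CCC2(CO1)[C@@H]1CCC3=C4[C@H](CC3=O)[C@H](C(=O)OC)C[C@@]42CN(C)C1`, gives > 40000 nM in this assay, also a limit.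

Compound 3 therefore stands nowhere that can be ranked: every value shown is a limit, as stated in the limit of > 40000 nM in this assay, at which 3 of the 3 values shown sit. Going by the values given here, the only measured step, a step that the two limits leave unreadable from compound 2 to compound 3, cannot be read because of the limit of > 40000 nM in this assay, at which 3 of the 3 values shown sit; the two compounds differ only in how one stereocentre is drawn, (the fact that one of compounds 2 and 3 is drawn with a defined configuration and the other without, at the place where they differ).

Compound 4, `CC[C@]1(OC)CCC2(CO1)[C@@H]1CCC3=C4[C@@H](CC3=O)[C@H](C(=O)OC)C[C@@]42CN(C)C1`, differs from compound 3 as follows: the two compounds have the same atoms and bonds; at least one stereo element is drawn with a configuration in one of them and without one in the other: 2 of 6 stereo elements differ; a stereocentre at a saturated ring carbon is drawn S in compound 3 and R in compound 4; a stereocentre at a saturated ring carbon is drawn R in compound 3 and S in compound 4. No measured step gives a readable size for a change of this kind, and no compound so far has shown a number in this assay. For compound 4 the expectation is therefore a further limit, an estimated 40000 nM with a range of 15000 nM to 100000 nM. The expected step of a number no higher from compound 3 to compound 4 (the limit leaves the size open) is estimated to lie within the scatter.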

Compound 4, half-maximal inhibitory concentration: > 40000 nM
Compound 4: a limit, no number (the forecaster's own chance of this, stated with the estimate: 85%); the middle value sits exactly at the limit.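

Compound 4 adds no readable step from compound 1, compound 2 or compound 3, because all four compounds sit at one limit and give no number: the limit of > 40000 nM in this assay, at which 4 of the 4 values shown sit. The compounds shown leave open whether these stereocentre changes, or hydrogen in place of methyl, alter the result in this assay at all.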